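Ring Contraction on the Amide Nitrogen of Compound 1

A few compounds are considered here, and "the series" means these few. Any claim that something is new, unique, unknown or untested is made for them only; others in the source may bear on it.

Two measured compounds frame this account. Compound 1 `CCC(C)C(NC(=O)n1nnc2ccccc21)C(=O)NC1CCCCC1` and compound 2 `CCC(C)C(NC(=O)NO)C(=O)NC(c1ccccc1)c1ccccc1` share the same acylated amino acid amide core but carry different groups on the amide nitrogen and on the urea nitrogen. In a functional assay on L1210 cells (Mus musculus) for inhibition (a lower number here means a stronger inhibitor, a higher number a weaker inhibitor), compound 1 gives 109000 nM, and compound 2 gives 54000 nM. Compound 1 therefore stands as the higher of the two numbers, above that of compound 2 by a gap beyond the usual scatter.

The step under consideration leads from compound 1 to compound 3 `CCC(C)C(NC(=O)n1nnc2ccccc21)C(=O)NC1CCCC1`, which is not yet measured in this assay. The change is cyclopentyl in place of cyclohexyl on an amide-type nitrogen. Among the compounds with values here, no measured pair in this set shows the effect of such a change, so there is no step to lean on. A swap of one carbocycle for another with one carbon fewer, on the same amide-type nitrogen, is expected to shift this assay little, probably within the scatter, with no direction favoured. Compound 3 is thus estimated at 100000 nM, within a range of 40000 nM to 250000 nM, implying an expected step of a 1.1-fold lower number from compound 1 to compound 3 (0.04 log units; within the scatter).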

Compound 3, half-maximal inhibitory concentration: 102000 nM
For compound 3 the middle estimate is 1.0-fold (0.01 log units) below the measured one; the range from low to high includes it.
By their numbers in this assay, from the lowest: compounds 2, 3 and 1 (each within the scatter of the next, the first and the last beyond it).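

Within the data shown here, this is the first pair in the set that differs in one place, and it gives the amide-type nitrogen its first direct reading: in this assay the exchange of cyclohexyl for cyclopentyl amounts to a 1.1-fold lower number from compound 1 to compound 3 (0.03 log units; within the scatter) and leaves the two compounds indistinguishable. On the shared core, then, a carbocycle of six carbons and one of five cannot be told apart at this position in this assay, with both compounds remaining in the same high range of numbers. Nothing further in the data bears on why the two read alike.

From the compounds shown here alone, a single step between two closely related carbocycles does not show how far this flatness extends, and whether cyclobutyl, cycloheptyl or an open chain such as n-hexyl on the same nitrogen would read the same in this assay remains open. Going by these compounds, it also remains open whether a group carrying an amine or a carboxylic acid at this position would move the number beyond the scatter, in either direction.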